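Amino for Chloro on the Shared Core of Three Alkylating Purines

This account rests on a few compounds, and the source may have more. Where it says the series, first, only, none or still open, it means among the compounds named here.

Measured compounds:
compound 1, `ClCc1ccc(Cn2cnc3c(Cl)ncnc32)cc1`, 2950 nM in a functional assay on OVCAR-5 cells (Homo sapiens) for cytotoxicity, read by sulforhodamine B assay, with a stated time of 48 h; a higher number here means a weaker inhibitor of growth, a lower number a stronger inhibitor of growth
compound 2, `ClCc1cccc(Cn2cnc3c(Cl)nc(Cl)nc32)c1`, 6450 nM
compound 3, `ClCc1ccccc1Cn1cnc2ncnc(Cl)c21`, 2810 nM

Compound 2 gives the highest of the three numbers in this assay. Compound 1 and compound 3 both lie lower; both gaps fall beyond the usual scatter, so compound 2 is the weakest of the three on these figures. Compound 1 and compound 3 lie within the scatter of each other.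

Compound 4, `Nc1nc(Cl)c2ncn(Cc3cccc(CCl)c3)c2n1`, has not been measured. It is built from compound 2 by a single change: amino in place of chloro on an aromatic carbon. For the measured compounds named here, no pair of measured compounds differs in only one place, so there is no comparable step to lean on. The expectation is therefore a cautious one. Compound 4 is expected to give a number near that of compound 2, perhaps somewhat lower, a step from compound 2 to compound 4 of a 1.4-fold lower number from compound 2 to compound 4 (0.16 log units; within the scatter) that would not be clearly beyond the scatter. Compound 4 is estimated at 4500 nM, with a range of 1500 nM to 13000 nM.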

Compound 4, concentration for 50% growth inhibition: 11000 nM
For compound 4 the middle estimate is 2.4-fold (0.39 log units) below the measured one; the range from low to high includes it.
By their numbers in this assay, from the lowest: compounds 3 and 1 (each within the scatter of the next); then compounds 2 and 4 (each within the scatter of the next).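

In this assay, for the compounds shown here, the change of chloro to amino on the aromatic carbon between two ring nitrogen atoms gives a 1.7-fold higher number from compound 2 to compound 4 (0.23 log units; within the scatter), the first step that can be read at a single place. On this evidence, the two groups cannot be told apart at this position, even though amino brings a hydrogen-bond donor and a hydrogen-bond acceptor that chloro does not, and the chloro group and the chloromethyl benzyl arm stay as they were in compound 2. Nothing available accounts for this result or shows what the exchange does in the cells, so the step stands as a plain observation.

On these data alone, whether other groups on this carbon, such as a methylamino group, a dimethylamino group, a hydroxyl or a methoxy group, would also stay within the scatter of compound 2 remains open. As far as these compounds go, it is also open whether an amino group at this carbon would behave the same way with the chloromethyl group placed as in compound 1 or compound 3, since this single step comes from the arrangement of compound 2 alone.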